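The source may report more compounds than this note shows. Statements on the series, on what has been measured and on what is new or still open speak of the compounds shown alone.

Compound 1 `COc1ccc(C(=O)/C=C/c2cccc(Cl)c2Oc2c([N+](=O)[O-])cc(C(F)(F)F)cc2[N+](=O)[O-])cc1`: 1.83 ug/mL
Compound 2 `O=C(/C=C/c1cccc(Cl)c1Oc1c([N+](=O)[O-])cc(C(F)(F)F)cc1[N+](=O)[O-])c1ccc(F)cc1`: 5.17 ug/mL
Compound 3 `O=C(/C=C/c1cccc(Br)c1Oc1c([N+](=O)[O-])cc(C(F)(F)F)cc1[N+](=O)[O-])c1ccc(Cl)cc1`: 4.74 ug/mL

In a functional assay on MCF7 cells (Homo sapiens) for antiproliferative activity, read by MTT assay, with a stated time of 48 h (a lower number here means a stronger inhibitor, a higher number a weaker inhibitor), compound 3 gives 4.74 ug/mL and compound 2 gives 5.17 ug/mL, two values within the usual scatter of each other. Compound 1 gives 1.83 ug/mL, the lowest number of the three and clearly apart from both others.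

Compound 4 `O=C(/C=C/c1cccc(Cl)c1Oc1c([N+](=O)[O-])cc(C(F)(F)F)cc1[N+](=O)[O-])c1ccc(Cl)cc1` differs from compound 3 in one place: chloro in place of bromo on an aromatic carbon. In words, this is chloro in place of bromo on an aromatic carbon. Going by the values given here, no measured step shows this swap. Among the compounds with values here, the only measured single-place step is a 2.8-fold higher number from compound 1 to compound 2 (0.45 log units; beyond the scatter), which is modest and beyond the scatter, but it is a different change, fluoro in place of methoxy, at a different place in the molecule. It offers no direct guide, so no step beyond the scatter is expected in this assay. The expected change is a 1.0-fold higher number from compound 3 to compound 4 (0.01 log units; within the scatter). Compound 4 is estimated at 4.8 ug/mL, with an expected range of 2.6 ug/mL to 8.8 ug/mL.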

Compound 4, half-maximal inhibitory concentration: 3.21 ug/mL
The estimate for compound 4 lay 1.5-fold (0.17 log units) above the measured number; measured number inside the range.
By their numbers in this assay, from the lowest: compounds 1, 4, 3 and 2 (each within the scatter of the next, the first and the last beyond it).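

In this assay chloro in place of bromo on the aromatic carbon ortho to a large group gives a 1.5-fold lower number from compound 3 to compound 4 (0.17 log units; within the scatter) and so shows that these two halogens cannot be told apart at this position. At the other changed place, chloro in place of fluoro gives a 1.6-fold lower number from compound 2 to compound 4 (0.21 log units; within the scatter) and chloro in place of methoxy gives a 1.8-fold higher number from compound 1 to compound 4 (0.24 log units; within the scatter) so chloro stays within the scatter of both groups, even though a 2.8-fold higher number from compound 1 to compound 2 (0.45 log units; beyond the scatter) separates those two from each other. Nothing measured here explains these numbers.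

The compounds shown carry only bromo or chloro at this position, so the effect of a quite different group there, such as an amine or a carboxylic acid, remains open. From the compounds shown here alone, whether methoxy would give the same number at this position as at the other place also remains open.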